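A Phenyl Substituent Replaces Methylsulfanyl on a Fused Core

This account rests on a few compounds, and the source may have more. Where it says the series, first, only, none or still open, it means among the compounds named here.

Of the compounds shown here, three sharing one fused core have been measured in a functional assay on HEK293 cells for antagonist activity at transient receptor potential cation channel subfamily V member 1 (Rattus norvegicus), read by calcium flux; on this read-out lower numbers stand for stronger inhibition and higher numbers for weaker inhibition. Compound 1 `CSc1ccc(Nc2ncnc3sc(Nc4c(Cl)cccc4Cl)nc23)cc1` gives 12 nM. Compound 2 `CSc1nc(Nc2ccc(C(F)(F)F)c(Cl)c2)c2nc(Nc3c(Cl)cccc3Cl)sc2n1` gives 113 nM, and compound 3 `CC(C)N1CCN(c2nc(Nc3ccc(C(F)(F)F)cc3)c3nc(Nc4c(Cl)cccc4Cl)sc3n2)CC1` gives 119 nM. Compound 2 holds the second highest of the three numbers; its nearest neighbour is compound 3, whose number lies within the scatter of its own, while compound 1 sits furthest away, with a number beyond the scatter below that of compound 2.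

Compound 4 `FC(F)(F)c1ccc(Nc2nc(-c3ccccc3)nc3sc(Nc4c(Cl)cccc4Cl)nc23)cc1Cl` has not yet been measured in this assay. It differs from compound 2 in one place: phenyl in place of methylsulfanyl on an aromatic carbon. Within the data shown here, no measured pair shows this kind of exchange, so its effect is unknown from the data at hand. Compound 2 and compound 3 carry different groups at this place, together with different anilines, and still return numbers within the scatter of each other, which gives little reason to expect a large shift. The step from compound 2 to compound 4 is expected to be a 1.3-fold higher number from compound 2 to compound 4 (0.12 log units; within the scatter), not beyond the scatter. Compound 4 is therefore estimated to give about 150 nM in this assay, within a range from 40 nM to 600 nM.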

Compound 4, half-maximal inhibitory concentration: 104 nM
Beside the measured number, compound 4's estimate is 1.4-fold (0.16 log units) above it; the range from low to high includes it.
By their numbers in this assay, from the lowest: compound 1; then compounds 4, 2 and 3 (each within the scatter of the next).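

Phenyl in place of methylsulfanyl on this aromatic carbon, between two ring nitrogen atoms, gives a 1.1-fold lower number from compound 2 to compound 4 (0.04 log units; within the scatter) in this assay and so leaves the number within the scatter. The position therefore accepts a six-membered aromatic ring of carbon only, with 6 heavy atoms in place of 2 and without the hydrogen-bond acceptor counted for methylsulfanyl, and no shift beyond the scatter follows. No supporting measurement is available to explain why the number holds.

As far as these compounds go, whether a carboxylic acid, a primary amine or a longer alkyl chain on this carbon would also stay within the scatter remains open. So does whether a phenyl carrying its own substituent, such as a nitrile, would behave like the plain phenyl of compound 4.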